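Ortho halogen swap on the aryl-isoxazole of compound 3

The compounds below may be only part of what the source reports. "The series", "measured", "known", "first", "only" and "open" are said of these compounds alone.

Of the compounds shown here, three sharing one core have been measured in a functional assay on MCF7 cells (Homo sapiens) for cytotoxicity, with a stated time of 48 h; on this read-out higher numbers stand for weaker inhibition and lower numbers for stronger inhibition. Compound 1 `O=[N+]([O-])c1ccc(CN2CCC(n3cc(CC(OCc4cc(-c5ccc(F)cc5)no4)c4ccc(Br)cc4)nn3)CC2)cc1` carries a 4-fluorophenyl on the aromatic carbon and in this assay compound 1 gives 7000 nM. Compound 2 `N#Cc1cccc(-c2cc(COC(Cc3cn(C4CCN(Cc5ccc([N+](=O)[O-])cc5)CC4)nn3)c3ccc(Br)cc3)on2)c1` carries a 3-cyanophenyl there, and compound 2 gives 2000 nM. Compound 3 `O=[N+]([O-])c1ccc(CN2CCC(n3cc(CC(OCc4cc(-c5ccccc5Br)no4)c4ccc(Br)cc4)nn3)CC2)cc1` carries a 2-bromophenyl, and compound 3 gives 6000 nM. Among these three numbers compound 3 stands second highest: a 1.2-fold lower number from compound 1 to compound 3 (0.07 log units; within the scatter), whereas a 3.0-fold higher number from compound 2 to compound 3 (0.48 log units; beyond the scatter).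

Compound 4 `O=[N+]([O-])c1ccc(CN2CCC(n3cc(CC(OCc4cc(-c5ccccc5F)no4)c4ccc(Br)cc4)nn3)CC2)cc1` differs from compound 3 in one place: fluoro in place of bromo on an aromatic carbon. Among the compounds with values here, no measured step exchanges one halogen for another on that ring. The closest guide is that the 2-bromophenyl of compound 3 and the 4-fluorophenyl of compound 1 give numbers that lie within the scatter of each other, so a single-atom halogen change at this position has not yet produced a shift of note, while the only substantial movement seen, toward compound 2, involved a nitrile rather than a halogen. The step from compound 3 to compound 4 is therefore expected to be small, no change at the digits printed from compound 3 to compound 4 (within the scatter), with no direction favoured beyond the scatter. Compound 4 is estimated at 6000 nM, with a range from 3000 nM to 12000 nM.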

Compound 4, half-maximal inhibitory concentration: 8000 nM
Beside the measured number, compound 4's estimate is 1.3-fold (0.12 log units) below it, and the stated range covers the measured number.
By their numbers in this assay, from the lowest: compound 2; then compounds 3, 1 and 4 (each within the scatter of the next).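

In this assay, within the data shown here, the exchange of bromo for fluoro on an aromatic carbon ortho to a large group gives a 1.3-fold higher number from compound 3 to compound 4 (0.12 log units; within the scatter), the first direct exchange of one halogen for another on this ring, and at this place it leaves the result within the scatter. The 2-fluorophenyl and 4-fluorophenyl groups, which carry the same halogen, give a 1.1-fold higher number from compound 1 to compound 4 (0.06 log units; within the scatter), so moving the fluoro also yields no difference that can be read, whereas compounds 1 and 3 differed in both the halogen and its place. The 3-cyanophenyl group of compound 2 remains the one clear departure among the four compounds, with a 4.0-fold higher number from compound 2 to compound 4 (0.60 log units; beyond the scatter), while the three halogen-bearing phenyl groups of compounds 1, 3 and 4 stay within the scatter of one another in the order of their numbers.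

The compounds shown do not tell whether the shift seen with compound 2 belongs to the nitrile itself or to its place on the ring, nor what an amine or a carboxylic acid on that phenyl would give. No measurement offered here explains the pattern.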